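This account rests on a few compounds, and the source may have more. Where it says the series, first, only, none or still open, it means among the compounds named here.

Measured in a functional assay on PC-3 cells (Homo sapiens) for cytotoxicity, read by sulforhodamine B assay, with a stated time of 72 h; on this read-out lower numbers stand for stronger inhibition and higher numbers for weaker inhibition:

- compound 1, `COC(=O)c1c(N)sc(-c2ccc(Cl)cc2)c1-c1ccc(Cl)cc1`, gives 2780 nM
- compound 2, `Nc1sc(-c2ccc(Cl)cc2)c(-c2ccc(Cl)cc2)c1C(=O)NC1CC1`, gives 3680 nM
- compound 3, `Nc1sc(-c2ccc(Cl)cc2)c(-c2ccc(Cl)cc2)c1C(=O)NC1CCCCC1`, gives 7300 nM

Compound 3 stands with the highest number of the three. Its nearest neighbour is compound 2, the step being a 2.0-fold higher number from compound 2 to compound 3 (0.30 log units; within the scatter); the step from the methyl ester is a 2.6-fold higher number from compound 1 to compound 3 (0.42 log units; beyond the scatter).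

Compound 4, `Nc1sc(-c2ccc(Cl)cc2)c(-c2ccc(Cl)cc2)c1C(=O)N1CCCC1`, differs from compound 3 in one place: pyrrolidin-1-yl in place of cyclohexylamino on a carbonyl carbon. The measured step that bears most closely on this change is the swap of one ring for another on the amide-type nitrogen, a 2.0-fold higher number from compound 2 to compound 3 (0.30 log units; within the scatter), which stayed within the scatter. The two steps from the ester, a 1.3-fold higher number from compound 1 to compound 2 (0.12 log units; within the scatter) and a 2.6-fold higher number from compound 1 to compound 3 (0.42 log units; beyond the scatter), show that the whole amide series sits close together, with at most a modest spread. Among the compounds with values here, no measured step removes the amide hydrogen, so that part of the change is untested here. On these numbers, the step from compound 3 to compound 4 is expected to be small in this assay, likely a somewhat lower number, a 1.5-fold lower number from compound 3 to compound 4 (0.16 log units; within the scatter). Compound 4 is therefore estimated at 5000 nM, within a range of 2000 nM to 15000 nM.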

Compound 4, half-maximal inhibitory concentration: 6220 nM
Compound 4: middle estimate off by 1.2-fold (0.09 log units), on the low side, within the range that was stated.
By their numbers in this assay, from the lowest: compounds 1, 2, 4 and 3 (each within the scatter of the next, the first and the last beyond it).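

In this assay, within the data shown here, the change gives a 1.2-fold lower number from compound 3 to compound 4 (0.07 log units; within the scatter), and this is the first step to take away the amide hydrogen, so at this carbonyl carbon the loss of that hydrogen, together with the change of ring, leaves the number within the scatter. Among these compounds, the comparison with the other secondary amide reads the same way, at a 1.7-fold higher number from compound 2 to compound 4 (0.23 log units; within the scatter), so the tertiary amide falls in with the two secondary amides, and only the step from the methyl ester, a 2.2-fold higher number from compound 1 to compound 4 (0.35 log units; beyond the scatter), lies beyond the scatter, and then only modestly. Nothing measured here accounts for how little this change moved the number.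

The compounds shown leave open whether a morpholin-4-yl or piperazin-1-yl group, or a free carboxylic acid, on this carbonyl carbon would stay in the same narrow band. All four compounds share one core, so they cannot tell how changes elsewhere on it would read.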